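Amine chain shortening in a calcium-flux agonist series

The source may hold more compounds than are shown below. What is called first, only, known or untested is meant among the compounds shown, and "the series" means these compounds.

Of the compounds shown here, three of the shared core have been measured in a functional assay on CCRF-CEM cells for agonist activity at C-X-C chemokine receptor type 4 (Homo sapiens), read by calcium flux, with a stated time of 25 min; on this read-out higher numbers stand for an effect only at larger amounts of compound and lower numbers for an effect already at smaller amounts. Compound 1 `CN(C[C@H]1Cc2c(cccc2N2CCN3CCC[C@H]3C2)CN1)[C@H]1CCCc2cccnc21` reaches only the limit of the assay, > 30000 nM. Compound 2 `C[C@@H]1CN(c2cccc3c2C[C@H](CN(C)[C@H]2CCCc4cccnc42)NC3)C[C@H](C)N1C` likewise returns a limit, > 30000 nM. Compound 3 `CCCN(C[C@H]1Cc2c(cccc2N2CCNCC2)CN1)[C@H]1CCCc2cccnc21` also sits at a limit, > 30000 nM, so it stands at the boundary of the read-out rather than at a number. The one single-point step within the set, a step that the two limits leave unreadable from compound 1 to compound 2, cannot be read, as the collected limits make plain: the limit of > 30000 nM in this assay, at which 3 of the 3 values shown sit. Among the measured compounds shown here, compound 3 carries propyl on the amine nitrogen; compound 1 carries methyl but differs from compound 3 in the ring group as well, so their two limits show only that neither compound gives a measurable effect.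

Compound 4 `CN(C[C@H]1Cc2c(cccc2N2CCNCC2)CN1)[C@H]1CCCc2cccnc21` is to be measured in this assay. Relative to compound 3 the change is hydrogen in place of ethyl on a saturated chain carbon bound to an amine nitrogen. For the measured compounds named here, no measured step bears on this change; the only step in the set is unreadable and all three values are limits. The expectation for compound 4 is therefore that it again reaches only the limit, with the step that the limit leaves unreadable from compound 3 to compound 4 expected to be nothing beyond the scatter in so far as it can be read at all. The estimate for compound 4 is 40000 nM, with a range from 15000 nM to 150000 nM, most probably reported as a limit.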

Compound 4, half-maximal effective concentration: > 30000 nM
Compound 4: a limit, no number (the forecaster's own chance of this, stated with the estimate: 85%); the middle value does not contradict the limit.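

Compound 4 also returns only a limit, so its steps from compound 1, compound 2 and compound 3 cannot be read, and the series still has no number: the limit of > 30000 nM in this assay, at which 4 of the 4 values shown sit.

The compounds shown leave open whether any group on the amine nitrogen or on the aromatic carbon gives a measurable effect in this assay.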